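Notes on the amino-to-methoxy change in the chalcone series

The source may hold more compounds than are shown below. What is called first, only, known or untested is meant among the compounds shown, and "the series" means these compounds.

Compound 1 `COc1cc(-c2cc(/C=C/C(=O)c3ccc(N)cc3)[nH]n2)cc(OC)c1OC` is the reference point here. In a functional assay on NCI-H23 cells (Homo sapiens) for inhibition, read by sulforhodamine B assay, with a stated time of 48 h (on this read-out higher numbers stand for weaker inhibition of growth and lower numbers for stronger inhibition of growth), compound 1 gives 2480 nM, the lowest of the two numbers recorded so far. Among the measured compounds shown here, its only measured neighbour is compound 2 `COc1ccc(-c2cc(/C=C/C(=O)c3ccc(N)cc3)[nH]n2)cc1OC`, which in this assay gives 4210 nM; the step of a 1.7-fold higher number from compound 1 to compound 2 (0.23 log units; within the scatter) is a change of hydrogen in place of methoxy on an aromatic carbon and does not rise above the scatter.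

Compound 3 `COc1ccc(C(=O)/C=C/c2cc(-c3cc(OC)c(OC)c(OC)c3)n[nH]2)cc1` is not yet measured. Relative to compound 1 the change is methoxy in place of amino on an aromatic carbon. For the measured compounds named here, no measured step touches this position or this kind of exchange: the single step available, from compound 1 to compound 2, concerns the other ring, and it was within the scatter. There is therefore no basis for expecting a shift in either direction beyond the scatter in this assay, and the estimate for compound 3 is placed close to the value of compound 1, with a wide band to reflect the absence of a bearing step. Compound 3 is expected to give 3000 nM in this assay, within a range from 1000 nM to 9000 nM. The expected step of a 1.2-fold higher number from compound 1 to compound 3 (0.08 log units; within the scatter) is an estimate only.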

Compound 3, concentration for 50% growth inhibition: 3040 nM
For compound 3 the middle estimate is 1.0-fold (0.01 log units) below the measured one; the measured number falls inside the stated range.
By their numbers in this assay, from the lowest: compounds 1, 3 and 2 (each within the scatter of the next).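

In this assay, the exchange at this position, on an aromatic carbon of the six-membered ring of carbon only and para to a large group, gives a 1.2-fold higher number from compound 1 to compound 3 (0.09 log units; within the scatter), so replacing 4-aminophenyl with 4-methoxyphenyl on the core of compound 1 produces no shift that can be told from the scatter. Among the compounds shown here, this is the first reading at this position, as the earlier step concerned the other ring, and it shows that on this core the amino group, with its hydrogen-bond donor, can give way to methoxy, which has none, without a resolved change in the number. Nothing at hand bears on why the two groups read alike, and this single pair gives no account of it.

The compounds shown leave open whether a larger exchange at this position, such as a carboxylic acid, a dimethylamino group or a longer alkoxy chain, would move the number beyond the scatter, or whether plain hydrogen there would do so. They also leave open whether methoxy in place of amino reads the same on the core of compound 2, which carries one methoxy fewer on the other ring.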